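The compounds below may be only part of what the source reports. "The series", "measured", "known", "first", "only" and "open" are said of these compounds alone.

Compound 1 `Nc1nc(N/N=C/c2ccc(N3CCCC3)cc2)nc2c1ncn2[C@@H]1O[C@H](CO)[C@@H](O)[C@H]1O` is the reference point. In an assay on CHO-K1 cells for displacement of a labelled ligand from adenosine receptor A1 (Homo sapiens), read by scintillation counting, with a stated time of 60 min (a lower number here means a stronger inhibitor, a higher number a weaker inhibitor), compound 1 gives 5.1 nM, the lowest number among the three measured compounds. Compound 3 `Nc1nc(N/N=C/c2ccc(-c3ccccn3)cc2)nc2c1ncn2[C@@H]1O[C@H](CO)[C@@H](O)[C@H]1O` gives 7540 nM in this assay, and compound 2 `COc1cc(/C=N/Nc2nc(N)c3ncn([C@@H]4O[C@H](CO)[C@@H](O)[C@H]4O)c3n2)ccc1OCc1ccccc1` gives 9140 nM; both of these numbers stand far above that of compound 1, so compound 1 is the strongest inhibitor of the three.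

Compound 4 `Nc1nc(N/N=C/c2cccnc2Cl)nc2c1ncn2[C@@H]1O[C@H](CO)[C@@H](O)[C@H]1O` has not yet been measured. It keeps the shared core of compound 1 and differs in one place: 2-chloropyridin-3-yl in place of 4-(pyrrolidin-1-yl)phenyl on a carbon with a double bond to nitrogen. The group that leaves is the 4-(pyrrolidin-1-yl)phenyl that compound 1 carries, and the 2-chloropyridin-3-yl takes its place.

For the measured compounds named here, one measured step bears on this change. Replacing pyrrolidin-1-yl by pyridin-2-yl on an aromatic carbon gave a 1500-fold higher number from compound 1 to compound 3 (3.17 log units; beyond the scatter), a large loss. Going by the values given here, compound 4 also loses the pyrrolidin-1-yl, and it further exchanges the remaining ring for the 2-chloropyridin-3-yl, a change for which no measured step exists. A large step toward a higher number, well beyond the scatter, is therefore expected in this assay, roughly a 590-fold higher number from compound 1 to compound 4 (2.77 log units; beyond the scatter). Compound 4 is estimated at 3000 nM, with an expected range from 400 nM to 25000 nM.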

Compound 4, inhibition constant: 4.6 nM
Beside the measured number, compound 4's estimate is 650-fold (2.81 log units) above it; the measured number lies below the stated range.
By their numbers in this assay, from the lowest: compounds 4 and 1 (each within the scatter of the next); then compounds 3 and 2 (each within the scatter of the next).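

In this assay, putting 2-chloropyridin-3-yl in place of the whole 4-(pyrrolidin-1-yl)phenyl on the carbon with a double bond to nitrogen gives a 1.1-fold lower number from compound 1 to compound 4 (0.04 log units; within the scatter), even though the entering group has fewer heavy atoms and no five-membered non-aromatic ring. The earlier step, a 1500-fold higher number from compound 1 to compound 3 (3.17 log units; beyond the scatter), tied the loss of pyrrolidin-1-yl to a large rise in the number, but the new step shows that a low number in this series does not require that ring, so the earlier loss does not apply to every compound lacking it. Nothing measured here gives a reason for the contrast between these two steps.

The compounds shown do not separate the part played by the chlorine from that of the ring nitrogen in 2-chloropyridin-3-yl, as neither a pyridine ring without the chlorine nor a phenyl ring carrying chlorine stands among them on this carbon. Also open, on these data alone, is how an amine or a methoxy group in place of the chlorine would read in this assay.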